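Hydroxymethyl to carboxy on the nitrogen chain

The source may hold more compounds than are shown below. What is called first, only, known or untested is meant among the compounds shown, and "the series" means these compounds.

In an assay on 32D cells for inhibition of interleukin-15 (Mus musculus), read by resazurin assay, with stated times of 30 min and 2.5 days, in the presence of a further agent that is not named here (on this read-out higher numbers stand for weaker inhibition and lower numbers for stronger inhibition), three compounds sharing one core have been measured. Compound 2 `Cn1nc(Cc2nnc(SCCCCCCCC(=O)Nc3ccc(Cl)cc3Cl)[nH]2)c2ccccc2c1=O`, carrying hydrogen on the aromatic nitrogen, gives 3500 nM. Compound 1 `CCOC(CCn1c(Cc2nn(C)c(=O)c3ccccc23)nnc1SCCCCCCCC(=O)Nc1ccc(Cl)cc1Cl)OCC` gives 16400 nM, and a 4.7-fold lower number from compound 1 to compound 2 (0.67 log units; beyond the scatter). Compound 3 `Cn1nc(Cc2nnc(SCCCCCCCC(=O)Nc3ccc(Cl)cc3Cl)n2CCCO)c2ccccc2c1=O` reaches only the assay limit of > 30000 nM, so no exact number is known for it. Accordingly an at least 8.5-fold higher number from compound 2 to compound 3 (0.93 log units; beyond the scatter), and an at least 1.8-fold higher number from compound 1 to compound 3 (0.26 log units; that floor lies within the scatter). Compound 4 `Cn1nc(Cc2nnc(SCCCCCCCC(=O)Nc3ccc(Cl)cc3Cl)n2CCC(=O)O)c2ccccc2c1=O` differs from compound 3 by carboxy in place of hydroxymethyl on a saturated chain carbon, two bonds along the chain from an aromatic nitrogen. The two substituents placed on this nitrogen so far, in compound 1 and compound 3, both weakened inhibition relative to compound 2, and a carboxy group there is expected to behave alike, keeping the number at or past the limit. Compound 4 is therefore estimated at 40000 nM, with a range of 15000 nM to 120000 nM. This estimate means an expected step that the limit leaves unreadable from compound 3 to compound 4.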

Compound 4, half-maximal inhibitory concentration: > 30000 nM
Compound 4 gave a limit, no number; the forecaster's own chance of this, stated with the estimate: 65%; the middle value lies beyond the limit too.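

With 2-carboxyethyl on this nitrogen, a second group ending in a hydroxyl-bearing carbon's replacement also leaves inhibition far weaker than with hydrogen: in this assay there is an at least 8.5-fold higher number from compound 2 to compound 4 (0.93 log units; beyond the scatter). Against the 3,3-diethoxypropyl group, the result gives only an at least 1.8-fold higher number from compound 1 to compound 4 (0.26 log units; that floor lies within the scatter). The steps involving both limits, including hydroxymethyl to carboxy, cannot be read: the limit of > 30000 nM in this assay, at which 2 of the 4 values shown sit.

Open, from the compounds shown here alone, is how far past the limit compound 3 and compound 4 lie. Also open, going by these compounds, is whether methyl, a shorter chain, or an amine at the chain end would keep the number close to that of compound 2.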